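The source may hold more compounds than are shown below. What is called first, only, known or untested is meant among the compounds shown, and "the series" means these compounds.

Of the compounds shown here, three of one family have been tested in an assay on H4 cells for inhibition of Fatty-acid amide hydrolase 1 (Homo sapiens); on this read-out lower numbers stand for stronger inhibition and higher numbers for weaker inhibition. Compound 1 `CCCCCCCOc1ccc(NC(=O)Oc2ccccc2F)cc1` carries a seven-carbon chain on one ring and a fluorine on the other; in this assay compound 1 gives 28 nM. Compound 2 `CCCCOc1ccc(C(CC)NC(=O)Oc2ccccc2F)cc1` has a shorter chain and an extra branch on the linker; in this assay compound 2 gives 7.7 nM. Compound 3 `CCCCOc1ccc(C(CC)NC(=O)Oc2cccc(C(F)(F)F)c2)cc1` keeps that branched linker but swaps the fluorine for a trifluoromethyl group; in this assay compound 3 gives 51 nM.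

Compound 3 therefore stands at the highest of the three numbers. Its reading and that of compound 1 lie within the usual scatter of each other, so no order between the two can be claimed. Against compound 2 the gap is clearly beyond the scatter, and compound 2 stands at the lower number.

Compound 4 `CCCCOc1ccc(C(CC)NC(=O)Oc2cccc(N(C)C)c2)cc1` has not yet been measured. It differs from compound 3 in one place: dimethylamino in place of trifluoromethyl on an aromatic carbon. For the measured compounds named here, no measured pair shows this exact change, so the expectation rests on the group names alone. The step of a 2.4-fold higher number from compound 3 to compound 4 (0.37 log units; beyond the scatter) is expected to be a moderate rise in the number, though possibly none beyond the scatter. Compound 4 is estimated at 120 nM, within a range from 30 nM to 500 nM.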

Compound 4, half-maximal inhibitory concentration: 54 nM
For compound 4 the middle estimate is 2.2-fold (0.35 log units) above the measured one; low and high end bracket the measured number.
By their numbers in this assay, from the lowest: compound 2; then compounds 1, 3 and 4 (each within the scatter of the next).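

In this assay, dimethylamino in place of trifluoromethyl on this aromatic carbon gives a 1.1-fold higher number from compound 3 to compound 4 (0.02 log units; within the scatter), so the two groups cannot be told apart at this position, although they have different atoms and only dimethylamino counts a hydrogen-bond acceptor. Compared with compound 2, 3-(dimethylamino)phenyl in place of 2-fluorophenyl gives a 7.0-fold higher number from compound 2 to compound 4 (0.85 log units; beyond the scatter), so compound 2 keeps the lower number against this second group as well as against the trifluoromethyl of compound 3. Nothing measured here explains why these two groups read alike or why both stand apart from the 2-fluorophenyl of compound 2.

The compounds shown leave open whether other groups on the same aromatic carbon, such as a methoxy group, a primary amine or a carboxylic acid, would also fall within the scatter of compounds 3 and 4. They also leave open whether the lower number of compound 2 belongs to the fluorine itself or to where it sits on the ring, which a lone fluorine on the aromatic carbon that carries dimethylamino in compound 4 would help to separate.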